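The compounds below may be only part of what the source reports. "The series", "measured", "known", "first", "only" and "open" are said of these compounds alone.

Measured so far in a physicochemical assay (a lower number here means that less compound is needed, a higher number that more compound is needed for the effect), for three compounds:

Compound 1 `CCCCCCCC/C=C/CCCCCCCC(=O)Nc1cc2c(cc1F)c(=O)c(C(=O)OCC)cn2CC` gives 751 ug/mL
Compound 2 `CCCCCCCCCCCCCCCC(=O)Nc1cc2c(cc1F)c(=O)c(C(=O)OCC)cn2CC` gives "not active" (no number reported)
Compound 3 `CCCCCCCCCCCCCC(=O)Nc1cc2c(cc1F)c(=O)c(C(=O)OCC)cn2CC` gives 286 ug/mL

Compound 2 has no place on the numerical scale. It was reported only as "not active" (no number reported) and so offers no number from which to count a step. The change to compound 4 `CCCCCCCCCCCCCCCCCC(=O)Nc1cc2c(cc1F)c(=O)c(C(=O)OCC)cn2CC` is ethyl in place of hydrogen on a saturated chain carbon, ten or more bonds along the chain from a carbonyl carbon and extends the saturated chain further. Among the compounds with values here, the only measured step that bears on this is a 2.6-fold lower number from compound 1 to compound 3 (0.42 log units; beyond the scatter) and it is a modest one. There the compound with the shorter chain needs less material. Within the data shown here, compound 3 also has a shorter chain than compound 2 and is the one saturated member with a number, while compound 2 gave none. With so few compounds this is a hint and not an established trend, and compound 1 gives a number despite its long chain. Among the measured compounds shown here, no step from compound 2 can be sized, so the expectation is only one of direction. Compound 4 is expected to stay at the high end of the scale or to give no number at all. For compound 4 the estimated value is 800 ug/mL with an expected range from 250 ug/mL to 2500 ug/mL if a number is reported.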

Compound 4, half-maximal effective concentration: 799 ug/mL
Compound 4: middle estimate off by 1.0-fold (0.00 log units), on the high side, within the range that was stated.
By their numbers in this assay, from the lowest: compound 3; then compounds 1 and 4 (each within the scatter of the next).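

In this assay, the saturated chains now have two numbers to compare: butyl in place of hydrogen on a saturated chain carbon gives a 2.8-fold higher number from compound 3 to compound 4 (0.45 log units; beyond the scatter), so between these two compounds the longer chain needs more material. Within the data shown here, this modest step is the first reading within the saturated chains, and it does not make a clean series: compound 2 lies between them in chain length yet has no number, so the steps that involve it cannot be read, while compound 4, with ethyl in place of hydrogen relative to compound 2, does give a number, and a missing number therefore does not simply follow from chain length. Compound 4 also shows a 1.1-fold higher number from compound 1 to compound 4 (0.03 log units; within the scatter), so no order can be placed between these two chains, and nothing at hand bears on why the numbers differ as they do.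

The compounds shown leave open whether a shorter chain than that of compound 3 would continue the direction seen here. They also leave open how a chain carrying a carboxylic acid or an amine would read in this assay.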